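This account rests on a few compounds, and the source may have more. Where it says the series, first, only, none or still open, it means among the compounds named here.

Compound 3, with the structure `Nc1ncnn2c([C@@H]3O[C@H](CO)[C@@H](O)[C@H]3O)cc(-c3ccc(F)cc3F)c12`, gives 59500 nM in a functional assay on HCT-116 cells (Homo sapiens) for antiproliferative activity, with a stated time of 72 h; on this read-out higher numbers stand for weaker inhibition and lower numbers for stronger inhibition. Among the measured compounds shown here, on the numbers so far it stands second highest of three; its nearest neighbour is compound 2, `Nc1ncnn2c([C@@H]3O[C@H](CO)[C@@H](O)[C@H]3O)cc(-c3ccc(Cl)cc3)c12`, which gives 59300 nM, the gap being a 1.0-fold higher number from compound 2 to compound 3 (0.00 log units; within the scatter). Compound 1, `Nc1ncnn2c([C@@H]3O[C@H](CO)[C@@H](O)[C@H]3O)cc(-c3ccccc3)c12`, gives 82600 nM, and the step of a 1.4-fold lower number from compound 1 to compound 3 (0.14 log units; within the scatter), like a 1.4-fold lower number from compound 1 to compound 2 (0.14 log units; within the scatter), is within the scatter. Compound 4, `Nc1ncnn2c([C@@H]3O[C@H](CO)[C@@H](O)[C@H]3O)cc(/C=C/c3ccccc3)c12`, arises from compound 3 by 2-phenylethenyl in place of 2,4-difluorophenyl on an aromatic carbon. None of the measured steps touches a group of this kind: each of them exchanges one substituted phenyl for another, and every one stays within the scatter, so the shared core has so far shown only weak, indistinguishable inhibition across three variations at the same place. For the measured compounds named here, since no measured step reaches beyond the scatter, he expects the step of a 1.0-fold higher number from compound 3 to compound 4 (0.00 log units; within the scatter) to be no larger than the scatter. For compound 4 he therefore estimates 60000 nM in this assay, with a range from 25000 nM to 150000 nM.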

Compound 4, half-maximal inhibitory concentration: 4800 nM
The estimate for compound 4 lay 13-fold (1.10 log units) above the measured number; measured number outside the range, below it.
By their numbers in this assay, from the lowest: compound 4; then compounds 2, 3 and 1 (each within the scatter of the next).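

In this assay, the position on the aromatic carbon two ring bonds from the ring nitrogen had seemed insensitive, yet 2-phenylethenyl separates compound 4 from all three phenyl-bearing compounds: a 12-fold lower number from compound 3 to compound 4 (1.09 log units; beyond the scatter), a 12-fold lower number from compound 2 to compound 4 (1.09 log units; beyond the scatter) and a 17-fold lower number from compound 1 to compound 4 (1.24 log units; beyond the scatter). So this place in the shared core does respond to the group it carries, and the exchange that shows this keeps the same number of heavy atoms and one six-membered aromatic ring, while adding a double bond outside aromatic rings and removing both fluorines. Nothing measured here accounts for the difference.

With only one such compound shown, the role of the double bond remains open, and a saturated 2-phenylethyl chain or an ethynyl link would test it. On these data alone, it is also open whether chloro or fluoro on the phenyl ring of the 2-phenylethenyl group would change the number.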